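A few compounds are considered here, and "the series" means these few. Any claim that something is new, unique, unknown or untested is made for them only; others in the source may bear on it.

In a functional assay on DLD-1 cells (Homo sapiens) for inhibition, read by MTT assay, with a stated time of 72 h (a higher number here means a weaker inhibitor, a lower number a stronger inhibitor), three compounds have been measured:

- compound 1 `COc1cc(Oc2cccc(Nc3ccccc3)c2)cc(OC)c1CNCc1ccccc1`: 5220 nM
- compound 2 `COc1cc(Oc2cccc(Nc3ccccc3)c2)cc(OC)c1CNCCNC(C)=O`: 6010 nM
- compound 3 `COc1ccc(CCCNCc2c(OC)cc(Oc3cccc(Nc4ccccc4)c3)cc2OC)cc1`: 2540 nM

Compound 3 has the lowest number of the three. The measured steps to it are a 2.1-fold lower number from compound 1 to compound 3 (0.31 log units; beyond the scatter) and a 2.4-fold lower number from compound 2 to compound 3 (0.37 log units; beyond the scatter), both modest and beyond the scatter. By contrast, a 1.2-fold higher number from compound 1 to compound 2 (0.06 log units; within the scatter) stays within the scatter.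

Compound 4 `COc1cc(Oc2cccc(Nc3ccccc3)c2)cc(OC)c1CCO` has not yet been measured. It carries hydroxymethyl in place of (3-(4-methoxyphenyl)propyl)amino on a saturated chain carbon bound to an aromatic carbon. This change goes further than any measured step, since all three measured compounds keep the amine nitrogen and none shows what losing it does. The three steps therefore bear on it only in part.

Compound 4 also gives up the chain that separates compound 3 from the other two. A return to about the level of compound 1 at 5220 nM and compound 2 at 6010 nM, or somewhat past it, is therefore expected, with a modest rise in the number and wide uncertainty. The expected change is a 3.5-fold higher number from compound 3 to compound 4 (0.55 log units; beyond the scatter). Compound 4 is estimated at 9000 nM, with an expected range from 3000 nM to 30000 nM.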

Compound 4, half-maximal inhibitory concentration: 18100 nM
For compound 4 the middle estimate is 2.0-fold (0.30 log units) below the measured one; the measured number falls inside the stated range.
By their numbers in this assay, from the lowest: compound 3; then compounds 1 and 2 (each within the scatter of the next); then compound 4.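

In this assay, putting hydroxymethyl on the saturated chain carbon bound to an aromatic carbon raises the number whichever amino group leaves: a 7.1-fold higher number from compound 3 to compound 4 (0.85 log units; beyond the scatter) and a 3.0-fold higher number from compound 2 to compound 4 (0.48 log units; beyond the scatter) and a 3.5-fold higher number from compound 1 to compound 4 (0.54 log units; beyond the scatter). All three steps lie beyond the scatter, which makes compound 4 the weakest of the four and shows that the gain seen with (3-(4-methoxyphenyl)propyl)amino does not survive this change. The earlier compounds differed only in what the amine nitrogen carries, whereas compound 4 is the first to lack that nitrogen, and each step to it is larger than any step among the three amines, though nothing shown explains this rise.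

Compound 4 loses the nitrogen and its substituent together, so the compounds shown cannot say how much of the rise belongs to either loss, and a primary amine in the same place would be needed to part the two. They also leave open whether a longer chain ending in the 4-methoxyphenyl ring, or a carboxylic acid in place of the hydroxyl, would move the number in either direction.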